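A Methyl Comes Off: From Compound 3 to Compound 4

A few compounds are considered here, and "the series" means these few. Any claim that something is new, unique, unknown or untested is made for them only; others in the source may bear on it.

Compound 1, `COc1cc(Br)c(C2C(C#N)=C(N)OC(c3c[nH]c4ccccc34)=C2C#N)cc1OC`, gives 26.7% in a functional assay, tested at 400 ug/mL; a higher number here means a stronger effect of the compound at the concentration tested, a lower number a weaker effect.
Compound 2, `COc1ccc(C2C(C#N)=C(N)OC(c3c[nH]c4ccccc34)=C2C#N)cc1OC`, gives 28.1% in this assay.
Compound 3, `Cc1ccccc1C1C(C#N)=C(N)OC(c2c[nH]c3ccccc23)=C1C#N`, gives 25.7% in this assay.

All three numbers sit within the scatter of one another, so compound 3 cannot be told apart from compound 1 or compound 2 on these data. The unmeasured compound 4, `N#CC1=C(N)OC(c2c[nH]c3ccccc23)=C(C#N)C1c1ccccc1`, differs from compound 3 by hydrogen in place of methyl on an aromatic carbon. Within the data shown here, two measured steps bear on it. The step of a number 2.4 percentage points lower from compound 2 to compound 3 (within the scatter) exchanged the whole aryl group on the saturated ring carbon, the methyl included, and moved nothing beyond the scatter. The step of a number 1.4 percentage points higher from compound 1 to compound 2 (within the scatter) removed a bromo from an aromatic carbon and likewise stayed within the scatter. Since removing a substituent, or swapping the entire aryl group, left this assay flat, the smaller change to compound 4 is expected to do the same, with a step of a number 0.3 percentage points higher from compound 3 to compound 4 (within the scatter). Compound 4 is therefore estimated at 26%, between 16% and 36%.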

Compound 4, a percentage reported as activity, at one concentration (the size of the read-out at that concentration, not a potency): 26.7%
The estimate for compound 4 lay 0.7 percentage points below the measured number; measured number inside the range.
By their numbers in this assay, from the lowest: compounds 3, 1, 4 and 2 (each within the scatter of the next).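

In this assay, the step of a number 1 percentage points higher from compound 3 to compound 4 (within the scatter) tests the methyl ortho to a large group directly, and the 2-methylphenyl to phenyl change leaves the read-out within the scatter. The step of a number 1.4 percentage points lower from compound 2 to compound 4 (within the scatter) adds that the unsubstituted phenyl on the saturated ring carbon cannot be told apart from the 3,4-dimethoxyphenyl, so a comparison that earlier involved two different substituted aryl groups now extends to an aryl group with no substituent at all.

The aryl groups shown carry only methyl, bromo or methoxy, so it remains open whether an amine or a carboxylic acid at this position would move the read-out beyond the scatter. No evidence at hand says why this change leaves the read-out where it is.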